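The source may report more compounds than this note shows. Statements on the series, on what has been measured and on what is new or still open speak of the compounds shown alone.

Compound 1 `C[C@H]1C=C2C=C[C@H](C)[C@H](CCC3C[C@@H](O)CC(=O)O3)[C@H]2[C@@H](OCc2ccc(Cl)cc2)C1` sits with the lower of the two numbers in hand: in an assay for inhibition of 3-hydroxy-3-methylglutaryl-coenzyme A reductase (Rattus norvegicus) (on this read-out higher numbers stand for weaker inhibition and lower numbers for stronger inhibition), compound 1 gives 170 nM. For the measured compounds named here, compound 2 `C=CCO[C@H]1C[C@@H](C)C=C2C=C[C@H](C)[C@H](CCC3C[C@@H](O)CC(=O)O3)[C@H]21` gives 370 nM in this assay, so the one measured step, a 2.2-fold higher number from compound 1 to compound 2 (0.34 log units; beyond the scatter), runs toward weaker inhibition when the 4-chlorophenyl on the saturated chain carbon bound to an oxygen on a saturated carbon is replaced by vinyl.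

Compound 3 `CO[C@H]1C[C@@H](C)C=C2C=C[C@H](C)[C@H](CCC3C[C@@H](O)CC(=O)O3)[C@H]21` is not yet measured. Against compound 1 the change is hydrogen in place of 4-chlorophenyl on a saturated chain carbon bound to an oxygen on a saturated carbon, that is, the (4-chlorobenzyl)oxy group is cut back to methoxy. Going by the values given here, the only step that bears on this is the one from compound 1 to compound 2, where losing the 4-chlorophenyl for vinyl already cost a modest amount beyond the scatter. Taking the group down further, to hydrogen, is expected to cost at least as much, in the same direction, so a step of a 3.5-fold higher number from compound 1 to compound 3 (0.55 log units; beyond the scatter) is estimated. Compound 3 is therefore expected to give about 600 nM in this assay, with a range from 250 nM to 1500 nM.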

Compound 3, half-maximal inhibitory concentration: 2810 nM
Compound 3: the middle estimate sits 4.7-fold (0.67 log units) below what was measured; the whole stated range lies below it.
By their numbers in this assay, from the lowest: compound 1; then compound 2; then compound 3.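

In this assay, the (4-chlorobenzyl)oxy group on the core of compound 1 proves far more important than the first step suggested: cutting it back to methoxy gives a 17-fold higher number from compound 1 to compound 3 (1.22 log units; beyond the scatter) as a large loss of inhibition. Most of that loss is seen only when the last carbon substituent goes, since a 7.6-fold higher number from compound 2 to compound 3 (0.88 log units; beyond the scatter) is a bigger step than a 2.2-fold higher number from compound 1 to compound 2 (0.34 log units; beyond the scatter) and vinyl therefore keeps much of what 4-chlorophenyl provides on the saturated chain carbon bound to an oxygen on a saturated carbon, with inhibition among these three compounds ordered 4-chlorophenyl, then vinyl, then hydrogen and no compound shown going against that order. No measurement at hand accounts for the size of these steps.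

The compounds shown leave open whether the 4-chlorophenyl result depends on the chlorine or on the ring alone, which a plain phenyl in the same place would separate, and whether ethyl in place of vinyl would hold the level of compound 2. Also open, as far as these compounds go, is whether the ether oxygen itself matters, a question that an amine in its place would address.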